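The compounds below may be only part of what the source reports. "The series", "measured", "known", "first", "only" and "open" are said of these compounds alone.

Measured compounds:
compound 1 `CSc1nn2cccnc2c1S(=O)(=O)c1ccccc1`, 115 nM
compound 2 `CNc1nn2cccnc2c1S(=O)(=O)c1ccccc1`, 3.89 nM
compound 3 `COCc1cc(C)nc2c(S(=O)(=O)c3ccccc3)c(SC)nn12`, 155 nM

Of the compounds shown here, three have been measured in a functional assay on HEK293 cells for antagonist activity at 5-hydroxytryptamine receptor 6 (Homo sapiens), read by cAMP accumulation, with a stated time of 2 h; on this read-out lower numbers stand for stronger inhibition and higher numbers for weaker inhibition. Compound 1 and compound 2 share one core and differ in a single place: methylamino in place of methylsulfanyl on an aromatic carbon. This change gave a 30-fold lower number from compound 1 to compound 2 (1.47 log units; beyond the scatter). Compound 3 carries a different core, and the difference between the two cores is not broken down here; in this assay compound 3 gives a value within the scatter of compound 1.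

Compound 4 `CNc1nn2c(COC)cc(C)nc2c1S(=O)(=O)c1ccccc1` has not yet been measured. It differs from compound 3 by methylamino in place of methylsulfanyl on an aromatic carbon, the same change as that from compound 1 to compound 2, at the same place on the ring.

Within the data shown here, because the one measured instance of this change produced a 30-fold lower number from compound 1 to compound 2 (1.47 log units; beyond the scatter), compound 4 is expected to show a step of similar size, a 26-fold lower number from compound 3 to compound 4 (1.41 log units; beyond the scatter). This expectation rests on a single pair, so the step may come out somewhat smaller on the other core. The value of compound 4 is therefore estimated at 6 nM, with a likely range from 2 nM to 20 nM.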

Compound 4, inhibition constant: 7.59 nM
For compound 4 the middle estimate is 1.3-fold (0.10 log units) below the measured one; the measured number falls inside the stated range.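

In this assay, methylamino in place of methylsulfanyl on an aromatic carbon gave a 20-fold lower number from compound 3 to compound 4 (1.31 log units; beyond the scatter), so the change again brought a large step on a second core. Set beside the earlier step, the new one does not differ from it beyond what repeated measurement would allow: the same change on two cores in this assay, a 30-fold lower number (1.47 log units; beyond the scatter) from compound 1 to compound 2 and a 20-fold lower number (1.31 log units; beyond the scatter) from compound 3 to compound 4, 1.4-fold (0.16 log units) apart, within the scatter of two such steps This shows that, for these two cores, the size of the step carried over from one to the other, but it rests on only two pairs in one assay, so it does not show that the step would hold on any further core, nor does it explain why the step arises.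

The compounds shown leave open whether a different group in the same place, such as an unsubstituted amine, dimethylamino or ethylamino, would give a step of like size. They also leave open how much each of the methoxymethyl and methyl groups on the core of compound 3 contributes on its own.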